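The compounds below may be only part of what the source reports. "The series", "measured", "known", "first", "only" and "open" are said of these compounds alone.

Measured so far:
compound 1, `COCCN1C(=O)CNc2ncc(-c3ccc(C(C)(C)O)nc3)nc21`: 77%
compound 2, `CO[C@H]1CC[C@@H](N2CC(=O)Nc3ncc(-c4ccc(C(C)(C)O)nc4)nc32)CC1`: 45%

Both numbers come from a functional assay on the whole organism (PC-3 cells) for inhibition, with Mus musculus as the target, in a xenograft, with a stated time of 24 h, at a dose of 100 mg/kg by the oral route; a lower number here means less inhibition, a higher number more inhibition at the dose given (going by the name of the read-out). In this assay, among the compounds with values here, compound 2 stands lowest of the two, and its only neighbour, compound 1, lies higher by a gap beyond the usual scatter. Within the data shown here, no pair of measured compounds differs in a single place, so no step between them is known, and the gap between compound 1 and compound 2 shows only what those two values show.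

Compound 3, `CO[C@H]1CC[C@H](CN2CC(=O)Nc3ncc(-c4ccc(C(C)(C)O)nc4)nc32)CC1`, has not yet been measured in this assay. It differs from compound 2 in one place: (4-methoxycyclohexyl)methyl in place of 4-methoxycyclohexyl on a nitrogen on an aromatic ring in a ring. Among the measured compounds shown here, nothing among the measured compounds covers such a change, so the size of the step is unknown; it is expected to be small, with no direction beyond the scatter. Compound 3 is therefore expected to give about 50%, within a range from 25% to 75%. The estimated step is a number 5 percentage points higher from compound 2 to compound 3 (within the scatter), which is expected to lie within the scatter.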

Compound 3, a percentage reported as inhibition, in the whole organism at one dose (the size of the read-out at that dose, not a potency): 0%
For compound 3 the middle estimate is 50 percentage points above the measured one, outside the stated range (below it).
By their numbers in this assay, from the lowest: compound 3; then compound 2; then compound 1.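

The position on this nitrogen turns out to be sensitive to a small change, which the two earlier values could not show. In this assay the group (4-methoxycyclohexyl)methyl in place of 4-methoxycyclohexyl gives a number 45 percentage points lower from compound 2 to compound 3 (beyond the scatter) in a single large step, although both groups hold the same six-membered carbon ring and the same counts of hydrogen-bond donors and acceptors. No measurement at hand accounts for this drop.

As far as these compounds go, whether a longer chain, an amine or a carboxylic acid on this nitrogen would give a similar number stays open. Within the data shown here, this is the only pair that differs in one place, so it also remains unknown whether the same change would give a step of this size on another compound.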